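Two Pyrazole Chalcones and a Methoxy Removed at Full Strength

A few compounds are considered here, and "the series" means these few. Any claim that something is new, unique, unknown or untested is made for them only; others in the source may bear on it.

The study covers two pairs of compounds built on different cores. Compound 1 `COc1cc(-c2cc(/C=C/C(=O)c3ccc(N)cc3)[nH]n2)cc(OC)c1OC` and compound 2 `COc1ccc(-c2cc(/C=C/C(=O)c3ccc(N)cc3)[nH]n2)cc1OC` share one core; compound 3 `COc1cc(C(=O)/C=C/c2cc(-c3cc(OC)c(OC)c(OC)c3)n[nH]2)cc(OC)c1OC` and compound 4 `COc1ccc(-c2cc(/C=C/C(=O)c3cc(OC)c(OC)c(OC)c3)[nH]n2)cc1OC` share the other. How the two cores differ is not broken down here.

In a functional assay on U-251 cells (Homo sapiens) for cytotoxicity, read by sulforhodamine B assay, with a stated time of 48 h, tested at 100 uM (a lower number here means a stronger effect, a higher number a weaker effect of the compound at the concentration tested), compound 1 gives -98%. Compound 2 gives -96% in this assay. The change between them is hydrogen in place of methoxy on an aromatic carbon, and the step it made is a number 2 percentage points higher from compound 1 to compound 2 (within the scatter). Compound 3 gives -99% in this assay; its values and those of compound 1 and compound 2 all lie within the scatter of one another, so no order among the three can be read from them.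

Compound 4 is not yet measured in this assay. It differs from compound 3 by hydrogen in place of methoxy on an aromatic carbon, the same change as from compound 1 to compound 2, with the same surroundings at the place. On the first core that change left the read-out essentially unmoved, so a similar outcome is expected on the second core: compound 4 is estimated to give -97%, within a range from -100% to -88%. The expected step is a number 2 percentage points higher from compound 3 to compound 4 (within the scatter), resting on the earlier step of a number 2 percentage points higher from compound 1 to compound 2 (within the scatter) and on compound 3 at -99%; the only caution is that the estimate depends on a single measured instance of the change.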

Compound 4, a percentage reported as activity, at one concentration (the size of the read-out at that concentration, not a potency): -94%
The estimate for compound 4 lay 3 percentage points below the measured number, within the range that was stated.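

In this assay, hydrogen in place of methoxy on the core of compound 3 gave a step of a number 5 percentage points higher from compound 3 to compound 4 (within the scatter). Set beside the same change on the core of compound 1, the two steps agree: the same change on two cores in this assay, a number 2 percentage points higher (within the scatter) from compound 1 to compound 2 and a number 5 percentage points higher (within the scatter) from compound 3 to compound 4, 3 percentage points apart, within the scatter of two such steps This shows that, at the one concentration tested, the change carried from one core to the other without a difference that can be told from the scatter, but it rests on only two pairs and does not show that the same would hold on any further core, nor, the read-out being the size of the effect at a single concentration, that the change would leave the effect unmoved at other concentrations on either core.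

The compounds shown carry only methoxy or hydrogen at this place, ortho to a methoxy group, so how a hydroxyl group, an ethoxy group or a chlorine atom there would read remains open. Going by these compounds, all four compounds also keep the same carbonyl-bearing chain, so what an amide or a carboxylic acid in its place would do in this assay is equally open.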